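This account rests on a few compounds, and the source may have more. Where it says the series, first, only, none or still open, it means among the compounds named here.

Measured compounds:
compound 1 `CC(C)(C)c1ccc(CNCCCNS(=O)(=O)c2cc(C(F)(F)F)cc(C(F)(F)F)c2)cc1` — in a functional assay on A2780 cells (Homo sapiens) for inhibition, read by MTT assay, with a stated time of 72 h (a lower number here means a stronger inhibitor of growth, a higher number a weaker inhibitor of growth), compound 1 gives 2900 nM
compound 2 `O=S(=O)(NCCCNCc1ccc(Cl)c(C(F)(F)F)c1)c1cc(C(F)(F)F)cc(C(F)(F)F)c1` — in this assay compound 2 gives 5900 nM
compound 3 `O=S(=O)(NCCCNCc1ccc(Br)cc1)c1cc(C(F)(F)F)cc(C(F)(F)F)c1` — in this assay compound 3 gives 2600 nM

Compound 2 has the highest number of the three in this assay. The step of a 2.0-fold higher number from compound 1 to compound 2 (0.31 log units; beyond the scatter) is modest but beyond the scatter, as is a 2.3-fold lower number from compound 2 to compound 3 (0.36 log units; beyond the scatter). Between compounds 1 and 3 the step of a 1.1-fold lower number from compound 1 to compound 3 (0.05 log units; within the scatter) lies within the scatter.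

Compound 4 `O=S(=O)(NCCCNCc1ccc(Cl)cc1)c1cc(C(F)(F)F)cc(C(F)(F)F)c1` is not yet measured. It differs from compound 2 in one place: hydrogen in place of trifluoromethyl on an aromatic carbon. The nearest measured comparison is a 2.3-fold lower number from compound 2 to compound 3 (0.36 log units; beyond the scatter), in which the trifluoromethyl is likewise removed and bromo rather than chloro remains on the ring. Compounds 1 and 3 give values within the scatter of each other, which suggests the halogen or tert-butyl at that position matters little here, so the change from compound 2 to compound 4 is expected to behave much like the step to compound 3. Compound 4 is therefore expected to give 2800 nM in this assay, with a range from 1500 nM to 5500 nM. The expected step is then a 2.1-fold lower number from compound 2 to compound 4 (0.32 log units; beyond the scatter), toward a lower number.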

Compound 4, concentration for 50% growth inhibition: 1800 nM
Beside the measured number, compound 4's estimate is 1.6-fold (0.19 log units) above it, and the stated range covers the measured number.
By their numbers in this assay, from the lowest: compounds 4, 3 and 1 (each within the scatter of the next); then compound 2.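

In this assay the trifluoromethyl ortho to a chloro group is now changed on its own: hydrogen in its place gives a 3.3-fold lower number from compound 2 to compound 4 (0.52 log units; beyond the scatter), whereas the step to compound 3 also exchanged the halogen. Compound 2, the only one of the four carrying this trifluoromethyl, has the highest number, while a 1.4-fold lower number from compound 3 to compound 4 (0.16 log units; within the scatter) and a 1.6-fold lower number from compound 1 to compound 4 (0.21 log units; within the scatter) show no separation of chloro from bromo or tert-butyl on the aromatic carbon. Nothing measured here bears on the reason for the step to hydrogen.

From the compounds shown here alone, whether the same step appears with bromo or tert-butyl in place of the chloro group remains open. Going by these compounds, it is also open whether a methyl, a methoxy or a nitrile at this place would sit with compound 2 or with compound 4.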